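Swapping a Trifluoromethyl Aryl for a Methyl Aryl

The source may report more compounds than this note shows. Statements on the series, on what has been measured and on what is new or still open speak of the compounds shown alone.

Compound 3 `C=CCn1c(=O)/c(=C\c2ccccc2C(F)(F)F)[nH]c(=O)/c1=C\c1ccccc1OC` stands second highest of the three numbers in a functional assay on A549 cells (Homo sapiens) for cytotoxicity, read by CCK-8 assay, with a stated time of 72 h (on this read-out lower numbers stand for stronger inhibition and higher numbers for weaker inhibition), where compound 3 gives 7000 nM. Its nearest neighbour is compound 2 `C=CCn1c(=O)/c(=C\c2ccccc2Cl)[nH]c(=O)/c1=C\c1ccccc1OC`, which gives 5300 nM; the gap is a 1.3-fold higher number from compound 2 to compound 3 (0.12 log units; within the scatter). Furthest off is compound 1 `C=CCn1c(=O)/c(=C\c2cccc(F)c2)[nH]c(=O)/c1=C\c1ccccc1OC`, which gives 19700 nM; the steps from it are a 3.7-fold lower number from compound 1 to compound 2 (0.57 log units; beyond the scatter) and a 2.8-fold lower number from compound 1 to compound 3 (0.45 log units; beyond the scatter).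

Compound 4 `C=CCn1c(=O)/c(=C\c2ccc(C)cc2)[nH]c(=O)/c1=C\c1ccccc1OC` differs from compound 3 in one place: 4-methylphenyl in place of 2-(trifluoromethyl)phenyl on a double-bonded chain carbon bound to an aromatic carbon. Among the compounds with values here, no measured step puts a 4-methylphenyl on this chain carbon, so the guidance is indirect. The two steps that exchange the ring on this carbon, a 3.7-fold lower number from compound 1 to compound 2 (0.57 log units; beyond the scatter) and a 2.8-fold lower number from compound 1 to compound 3 (0.45 log units; beyond the scatter), were modest and ran toward lower numbers when 2-chlorophenyl or 2-(trifluoromethyl)phenyl replaced 3-fluorophenyl, while a 1.3-fold higher number from compound 2 to compound 3 (0.12 log units; within the scatter) shows that trifluoromethyl in place of chloro leaves the number within the scatter. A 4-methylphenyl has no precedent among these compounds, so the expected step in this assay is small and of uncertain direction, leaning toward a somewhat higher number. Compound 4 is therefore estimated at 12000 nM, with a range from 4000 nM to 35000 nM, which means an expected step of a 1.7-fold higher number from compound 3 to compound 4 (0.23 log units; within the scatter).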

Compound 4, half-maximal inhibitory concentration: "not active" (no number reported)
For compound 4 the study gives words and no number; the estimate stays without a comparison.
By their numbers in this assay, from the lowest: compounds 2 and 3 (each within the scatter of the next); then compound 1.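

In this assay, within the data shown here, compound 4 is reported as "not active", in words and without a number, so no step between compound 3 and compound 4 can be read. The compounds shown leave open how far a 4-methylphenyl on this chain carbon shifts the number. No data given here bear on the reason for this result.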